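Swapping One Benzyl Arm of Compound 3 for Another

A few compounds are considered here, and "the series" means these few. Any claim that something is new, unique, unknown or untested is made for them only; others in the source may bear on it.

Compound 1, `COc1cc(C[C@H]2C(=O)OC[C@@H]2Cc2ccccc2)cc(OC)c1OC`: in a functional assay on HL-60 cells (Homo sapiens) for cytotoxicity, read by WST assay, with a stated time of 48 h (a lower number here means that less compound is needed, a higher number that more compound is needed for the effect), compound 1 reaches only a limit of the assay, > 100000 nM.
Compound 2, `CCCCOc1ccc(C[C@H]2COC[C@@H]2Cc2ccccc2)cc1`: compound 2 gives 11000 nM.
Compound 3, `O=C1OC[C@H](Cc2ccccc2O)[C@H]1Cc1ccc(Cl)c(Cl)c1`: compound 3 gives 33000 nM.

Among the two compounds that return a real number, compound 3 stands at the higher end: its value lies a good deal above that of compound 2, and the gap between them is larger than the scatter of repeated measurements. Compound 1 sits at a limit of the assay and so cannot be ranked against the others. Going by the values given here, because of the limit of > 100000 nM in this assay, at which 1 of the 3 values shown sits, that reading says only that more compound than the assay can test would be needed.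

The next compound, compound 4, is `O=C1OC[C@H](Cc2ccc(Cl)c(Cl)c2)[C@H]1Cc1ccc(Cl)c(Cl)c1`. It arises from compound 3 by a single change: 3,4-dichlorophenyl in place of 2-hydroxyphenyl on a saturated chain carbon bound to a saturated ring carbon. Both arms of the core then carry the same dichlorinated ring. Among the compounds with values here, no measured pair in this set shows what such a swap does, so the expectation rests on compound 3 alone. A modest drop in the number is expected, with the step of a 2.2-fold lower number from compound 3 to compound 4 (0.34 log units; beyond the scatter), though it could also stay within the scatter. Compound 4 is therefore estimated at 15000 nM, within a range from 4000 nM to 60000 nM.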

Compound 4, half-maximal effective concentration: 20000 nM
For compound 4 the middle estimate is 1.3-fold (0.12 log units) below the measured one, and the stated range covers the measured number.
By their numbers in this assay, from the lowest: compounds 2, 4 and 3 (each within the scatter of the next, the first and the last beyond it). At a limit, above all of these: compound 1.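

Going by these compounds alone, replacing the 2-hydroxyphenyl on a saturated chain carbon bound to a saturated ring carbon gives the first direct comparison at this position: in this assay, the swap to 3,4-dichlorophenyl gives a 1.7-fold lower number from compound 3 to compound 4 (0.22 log units; within the scatter). The two groups differ clearly in what they carry, since 2-hydroxyphenyl has one hydrogen-bond donor and one hydrogen-bond acceptor, whereas 3,4-dichlorophenyl has neither and brings two chlorine atoms instead, yet this pair cannot be told apart in this read-out. Within the data shown here, nothing measured here explains why the number stays within the scatter, so this pair shows only that this one swap is tolerated at this position, and gives no cause for it.

Among these compounds, because the hydroxyl group leaves and both chlorine atoms enter in a single step, the share of each in this outcome stays unknown, and a ring carrying only one of these changes would be needed to separate them. As far as these compounds go, it also remains open whether a more different group on this arm, such as an amine or a carboxylic acid, would move the number beyond the scatter.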